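The compounds below may be only part of what the source reports. "The series", "measured", "known", "first", "only" and "open" are said of these compounds alone.

Measured compounds:
compound 1 `CNC(=O)c1cc(Oc2ccc(NC(=O)c3nn(-c4ccccc4OC(F)(F)F)c(=O)cc3C)cc2F)ccn1`
compound 2 `Cc1cc(=O)n(-c2ccccc2OC(F)(F)F)nc1C(=O)Nc1ccc(Oc2ncnc3ccsc23)cc1`

In a functional assay on MCF7 cells (Homo sapiens) for cytotoxicity, read by MTT assay, with a stated time of 72 h (a lower number here means a stronger inhibitor, a higher number a weaker inhibitor), compound 1 only reaches a limit of the test, > 40000 nM. Compound 2 gives 23800 nM in this assay. For the measured compounds named here, compound 2 thus holds the only real number, a weak one, while the other value sits at the limit of > 40000 nM in this assay, at which 1 of the 2 values shown sits.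

Compound 3 `Cc1cc(=O)n(-c2ccc(F)c(F)c2)nc1C(=O)Nc1ccc(Oc2ncnc3ccsc23)cc1` differs from compound 2 by 3,4-difluorophenyl in place of 2-(trifluoromethoxy)phenyl on an aromatic nitrogen. Going by the values given here, no measured step of this kind exists, so the step expected from compound 2 to compound 3, a 1.1-fold higher number from compound 2 to compound 3 (0.02 log units; within the scatter), is none beyond the usual scatter. Compound 3 is expected near 25000 nM, between 8000 nM and 80000 nM.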

Compound 3, half-maximal inhibitory concentration: 5550 nM
The estimate for compound 3 lay 4.5-fold (0.65 log units) above the measured number; measured number below the stated range.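

For the compounds shown here, this is the first step between compounds that differ in one place: in this assay, 3,4-difluorophenyl in place of 2-(trifluoromethoxy)phenyl on the aromatic nitrogen gives a 4.3-fold lower number from compound 2 to compound 3 (0.63 log units; beyond the scatter). The group on this nitrogen can therefore change the reading in this test, and here the entering group has fewer heavy atoms than the one it replaces. Nothing shown gives a reason for this step.

The compounds shown leave open whether the fluorines themselves or their places on the ring matter. A plain phenyl or a methoxyphenyl group on this nitrogen would bear on that question.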